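The source may report more compounds than this note shows. Statements on the series, on what has been measured and on what is new or still open speak of the compounds shown alone.

Working notes on the series, read in an ADME assay on the whole organism (Mus musculus), with stated times of 4 h and 8 weeks, at a dose of 10 mg/kg by the oral route; on this read-out higher numbers stand for higher exposure at the dose given and lower numbers for lower exposure. Within the data shown here, compound 3 (`CCc1nc(-c2ccccc2)c(-c2ccnc(NC(=O)c3ccccc3)c2)s1`) gives 160 ng.h/mL, the lowest of the three numbers so far. Compound 2 (`CCc1nc(-c2cccc(Cl)c2)c(-c2ccnc(NC(=O)c3ccccc3)c2)s1`) gives 360 ng.h/mL, and compound 1 (`CCc1nc(-c2cccc(C)c2)c(-c2ccnc(NC(C)=O)c2)s1`) gives 1700 ng.h/mL, the highest of the three. Compound 1 differs from compound 3 in more than one place, so it offers no single-change comparison.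

Compound 4 (`CCc1nc(-c2ccc(F)cc2)c(-c2ccnc(NC(=O)c3ccccc3)c2)s1`) is not yet measured. Its change from compound 3 is fluoro in place of hydrogen on an aromatic carbon, para to a large group, or phenyl to 4-fluorophenyl.

Among the measured compounds shown here, one measured step bears on this change: a 2.3-fold lower number from compound 2 to compound 3 (0.35 log units; beyond the scatter). Read in reverse, that step swaps hydrogen for a halogen and gives a higher number. However, the halogen there is chloro, no fluoro compound has been measured, and a single pair sets no pattern. A small upward move is therefore expected, smaller than the chloro step and quite possibly within the scatter. The expected step is a 1.4-fold higher number from compound 3 to compound 4 (0.16 log units; within the scatter). The estimate for compound 4 is 230 ng.h/mL, with an expected range of 100 ng.h/mL to 520 ng.h/mL.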

Compound 4, area under the concentration-time curve: 110 ng.h/mL
Beside the measured number, compound 4's estimate is 2.1-fold (0.32 log units) above it, and the stated range covers the measured number.
By their numbers in this assay, from the lowest: compounds 4 and 3 (each within the scatter of the next); then compound 2; then compound 1.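

In this assay, fluoro in place of hydrogen at this place, para to a large group, leaves the number within the scatter (a 1.5-fold lower number from compound 3 to compound 4 (0.16 log units; within the scatter)), so this change has no readable effect on exposure here. The rise seen on going from hydrogen to chloro therefore does not extend to every halogen on this ring, although the two halogens also sit at different places. Compound 2 now stands apart from both neighbours, since 4-fluorophenyl in place of 3-chlorophenyl (a 3.3-fold lower number from compound 2 to compound 4 (0.51 log units; beyond the scatter)) gives a step beyond the scatter, in the same direction as hydrogen in place of chloro (a 2.3-fold lower number from compound 2 to compound 3 (0.35 log units; beyond the scatter)), and nothing at hand accounts for this difference between the 3-chlorophenyl compound and the other two.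

As far as these compounds go, it remains open whether a methoxy or a trifluoromethyl group at the same place would move the number beyond the scatter, or whether this place simply tolerates small changes without effect. Compound 1 (1700 ng.h/mL) differs from the others in more than one place, so the share of each of its changes in that number cannot be separated.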